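Swapping the Aryl Group on the Weakest Compound

A few compounds are considered here, and "the series" means these few. Any claim that something is new, unique, unknown or untested is made for them only; others in the source may bear on it.

Measured compounds:
compound 1, `N#Cc1ccc(NC(=S)N/N=C/c2ccc3ccccc3n2)cc1`: 20000 nM
compound 2, `NC(=S)N/N=C/c1nc2ccccc2s1`: 5350 nM
compound 3, `CN(C)C(=S)N/N=C/c1cnc2ccccc2n1`: 750 nM

In a functional assay on HeLa cells (Homo sapiens) for antiproliferative activity, read by sulforhodamine B assay, with a stated time of 72 h (a higher number here means a weaker inhibitor, a lower number a stronger inhibitor), compound 1 gives 20000 nM, the highest of the three numbers and so the weakest inhibitor of the set. Compound 2 gives 5350 nM, a gap to compound 1 that lies beyond the usual scatter, and compound 3 gives 750 nM, the lowest number shown and well beyond the scatter from compound 1. The three compounds differ in several places at once, so no single change can be read from them.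

Compound 4, `Cc1ccccc1NC(=S)N/N=C/c1ccc2ccccc2n1`, differs from compound 1 in one place: 2-methylphenyl in place of 4-cyanophenyl on an amide-type nitrogen. Among the compounds with values here, no pair among the measured compounds isolates this exchange, so there is nothing to set the size of the step against. The arylthiourea end of compound 1 is the one that carries the highest number here, and the new group keeps that arrangement. The step from compound 1 to compound 4 is therefore expected to be modest, a 2.0-fold lower number from compound 1 to compound 4 (0.30 log units; within the scatter), with a slight lean toward a lower number. Compound 4 is estimated at 10000 nM, within a range from 3000 nM to 40000 nM.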

Compound 4, half-maximal inhibitory concentration: > 100000 nM
Compound 4: no number, only a limit; the forecaster's own chance of this, stated with the estimate: 15%; middle value at least 10-fold (1.00 log units) from the limit.
By their numbers in this assay, from the lowest: compound 3; then compound 2; then compound 1. At a limit, above all of these: compound 4.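

In this assay compound 4 gives > 100000 nM, which is a limit of the assay and not a number. Within the data shown here, exchanging 4-cyanophenyl for 2-methylphenyl on the amide-type nitrogen gives an at least 5.0-fold higher number from compound 1 to compound 4 (0.69 log units; beyond the scatter), so the reading for the core of compound 1 depends on which aryl group sits at this place, something the earlier compounds, differing in several places at once, could not show. The full size of the step stays unknown, as the reading for compound 4 rests on a limit: the limit of > 100000 nM in this assay, at which 1 of the 4 values shown sits.

From the compounds shown here alone, the exchange removes the nitrile and brings in the methyl together, and it remains open which of the two carries the step. Also open, going by these compounds, is how an unsubstituted phenyl or a 4-methoxyphenyl at this place would read in this assay.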